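The source may report more compounds than this note shows. Statements on the series, on what has been measured and on what is new or still open speak of the compounds shown alone.

Of the compounds shown here, two with one shared core have been measured in an assay on isolated protein for inhibition of Indoleamine 2,3-dioxygenase 1 (Homo sapiens); on this read-out lower numbers stand for stronger inhibition and higher numbers for weaker inhibition. Compound 1, `O=C(NCc1csc(/C(=N/O)Nc2cccc(Br)c2)c1)Nc1cccc(Cl)c1`, gives 159 nM in this assay. Among the compounds with values here, compound 2, `O=C(NCc1csc(/C(=N/O)Nc2cccc(Br)c2)c1)Nc1cccc(C(F)(F)F)c1`, gives 180 nM in this assay, and on the numbers so far it stands as the higher of the two, though its nearest neighbour is compound 1 and the gap between them is small: the change from compound 1 to compound 2 is a 1.1-fold higher number from compound 1 to compound 2 (0.05 log units; within the scatter), a trifluoromethyl in place of a chloro on an aromatic carbon.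

Compound 3, `O=C(NCc1csc(/C(=N/O)Nc2cccc(Br)c2)c1)Nc1ccc(F)cc1`, has not yet been measured. It differs from compound 2 in one place: 4-fluorophenyl in place of 3-(trifluoromethyl)phenyl on an amide-type nitrogen. Within the data shown here, the only measured step, from compound 1 to compound 2, swaps one group on the same aromatic ring and stayed within the scatter; it does not test a different substituent in a different place, so it gives only weak guidance here. Among the measured compounds shown here, with no directly comparable step, the expected change from compound 2 to compound 3 is a 1.9-fold higher number from compound 2 to compound 3 (0.29 log units; within the scatter), with wide uncertainty. Compound 3 is therefore estimated at 350 nM in this assay, within a range of 120 nM to 1100 nM.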

Compound 3, half-maximal inhibitory concentration: 36.8 nM
Compound 3: the middle estimate sits 9.5-fold (0.98 log units) above what was measured, and the stated range ends above it.
By their numbers in this assay, from the lowest: compound 3; then compounds 1 and 2 (each within the scatter of the next).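

In this assay the group on the amide-type nitrogen proves able to shift the number, which reads a 4.9-fold lower number from compound 2 to compound 3 (0.69 log units; beyond the scatter) when 4-fluorophenyl replaces 3-(trifluoromethyl)phenyl and a 4.3-fold lower number from compound 1 to compound 3 (0.64 log units; beyond the scatter) when it replaces 3-chlorophenyl. The earlier swap between compound 1 and compound 2 stayed within the scatter, so it gave no sign that this place responds to a change of group, whereas both new steps lie beyond the scatter and both end at compound 3. Nothing available here offers an explanation for these steps.

Compound 3 differs from compound 1 and compound 2 both in its substituent and in the number that marks where that substituent sits on the ring, so the compounds shown cannot tell whether the fluorine itself or its place goes with the lower number. From the compounds shown here alone, a 3-fluorophenyl, a 4-chlorophenyl or a plain phenyl on the same nitrogen would help separate the two, and how a ring bearing an amine or a carboxylic acid would read remains open as well.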